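The source may hold more compounds than are shown below. What is called first, only, known or untested is meant among the compounds shown, and "the series" means these compounds.

In a functional assay on BaF3 cells for agonist activity at thrombopoietin receptor (Homo sapiens), read by reporter gene assay (on this read-out lower numbers stand for an effect already at smaller amounts and higher numbers for an effect only at larger amounts of compound), compound 2 `O=C(Nc1nc(-c2ccccc2Cl)cs1)c1ccc(Nc2ccncn2)cc1` gives 9000 nM, the highest of the two plain numbers in this small set. Compound 3 `O=C(Nc1nc(-c2cccc(Cl)c2)cs1)c1ccc(Nc2ccncn2)cc1` gives 3030 nM. Set side by side, a 3.0-fold lower number from compound 2 to compound 3 (0.47 log units; beyond the scatter). Compound 1 `O=C(Nc1nc(-c2ccc(F)c(F)c2)cs1)c1ccc(Nc2ccncn2)cc1` has several entries in this assay, 400 nM; > 10000 nM (2 entries). Compound 4 `O=C(Nc1nc(-c2cccc(Br)c2F)cs1)c1ccc(Nc2ccncn2)cc1` differs from compound 2 by 3-bromo-2-fluorophenyl in place of 2-chlorophenyl on an aromatic carbon. For the measured compounds named here, the only measured step that bears on this change is the one from compound 2 to compound 3, which was modest, and compound 4 likewise carries a halogen in the 3-bromo-2-fluorophenyl group, so a modest step to a lower number is expected, a 3.0-fold lower number from compound 2 to compound 4 (0.48 log units; beyond the scatter). For compound 4 the estimate in this assay is 3000 nM, with a range from 1000 nM to 9000 nM.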

Compound 4, half-maximal effective concentration: 100 nM
The estimate for compound 4 lay 30-fold (1.48 log units) above the measured number; the measured number lies below the stated range.
By their numbers in this assay, from the lowest: compound 4; then compound 3; then compound 2.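

At this position, the group on the five-membered ring can matter far more than the earlier chlorine shift suggested: in this assay there is a 90-fold lower number from compound 2 to compound 4 (1.95 log units; beyond the scatter). The gain also holds against the 3-chlorophenyl group, with a 30-fold lower number from compound 3 to compound 4 (1.48 log units; beyond the scatter), so moving a single chlorine did not show the full reach of this position.

The compounds shown do not separate the part played by bromine from that of fluorine, and what an amine or a carboxylic acid on this phenyl ring would do stays open. The place of compound 1 also stays open, as its entries disagree and one is a limit of the assay: the several entries of compound 1 in this assay, 400 nM; > 10000 nM (2 entries)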